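The source may report more compounds than this note shows. Statements on the series, on what has been measured and on what is new or still open speak of the compounds shown alone.

Compound 3 `COc1cc(Cl)cc(-c2nn(-c3cccc(NC(=O)Nc4cccc(C(F)(F)F)c4)c3)cc2-c2ccncc2)c1` gives -4.59% in a functional assay on UO-31 cells (Homo sapiens) for inhibition, read by sulforhodamine B assay, with a stated time of 48 h, tested at 10 uM (on this read-out higher numbers stand for a weaker effect at the one concentration tested and lower numbers for a stronger effect), the lowest of the three numbers measured, though not separated from its nearest neighbour. Compound 2 `COc1cc(Cl)cc(-c2nn(-c3cccc(NC(=O)Nc4ccc(Cl)c(Cl)c4)c3)cc2-c2ccncc2)c1` gives 0.64% in this assay, and the two lie within the scatter of each other; compound 1 `COc1cc(Cl)cc(-c2nn(-c3cccc(NC(=O)c4ccc(Cl)c(Cl)c4)c3)cc2-c2ccncc2)c1` gives 43.5% in this assay, well beyond the scatter from both. Compound 4 `COc1cc(Cl)cc(-c2nn(-c3cccc(NC(=O)c4cccc(C(F)(F)F)c4)c3)cc2-c2ccncc2)c1` differs from compound 3 by 3-(trifluoromethyl)phenyl in place of (3-(trifluoromethyl)phenyl)amino on a carbonyl carbon. Among the compounds with values here, two measured steps bear on this change and run the opposite way, each replacing an aryl group on the carbonyl carbon with an arylamino group: a number 42.9 percentage points lower from compound 1 to compound 2 (beyond the scatter) and a number 48.1 percentage points lower from compound 1 to compound 3 (beyond the scatter), both large. Reversing that direction, the expected step is a number 44.6 percentage points higher from compound 3 to compound 4 (beyond the scatter), a large rise in this assay. Compound 4 is therefore estimated at 40% in this assay, within a range from 20% to 62%.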

Compound 4, a percentage reported as activity, at one concentration (the size of the read-out at that concentration, not a potency): 37.3%
For compound 4 the middle estimate is 2.7 percentage points above the measured one; measured number inside the range.
By their numbers in this assay, from the lowest: compounds 3 and 2 (each within the scatter of the next); then compounds 4 and 1 (each within the scatter of the next).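

Compound 4 shows that the loss on removing the amino nitrogen from the carbonyl carbon in this assay is not confined to the 3,4-dichlorophenyl series: the matched trifluoromethyl pair gives a large rise (a number 41.9 percentage points higher from compound 3 to compound 4 (beyond the scatter)), and the step across both changes is also large (a number 36.7 percentage points higher from compound 2 to compound 4 (beyond the scatter)). With the aryl group directly on the carbonyl carbon, exchanging the two aryl groups changes little (a number 6.2 percentage points lower from compound 1 to compound 4 (within the scatter)), so across these four compounds the linkage separates the numbers, not the aryl substituents. Nothing available explains this difference.

From the compounds shown here alone, whether an oxygen or a methylene in place of the amino nitrogen would keep the low numbers remains open.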